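A Second Chloro on the Core of Compound 2

The compounds below may be only part of what the source reports. "The series", "measured", "known", "first", "only" and "open" are said of these compounds alone.

Of the compounds shown here, three have so far been measured in a functional assay on EKVX cells (Homo sapiens) for cytotoxicity, read by sulforhodamine B assay, with a stated time of 48 h; a higher number here means that more compound is tolerated, a lower number that less compound is tolerated. Compound 1 `ClCc1ccccc1Cn1cnc2c(Cl)ncnc21` gives 37200 nM. Compound 2 `ClCc1cccc(Cn2cnc3ncnc(Cl)c32)c1` gives 64600 nM, and compound 3 `ClCc1cccc(Cn2cnc3c(Cl)ncnc32)c1` gives 63100 nM. Compound 2 stands with the highest of the three numbers, but compound 3, the nearest to it, lies within the scatter of it, and so does compound 1, the furthest of the three; no order can be read among them.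

Compound 4 `ClCc1cccc(Cn2cnc3nc(Cl)nc(Cl)c32)c1` has not yet been measured in this assay. It differs from compound 2 in one place: chloro in place of hydrogen on an aromatic carbon. For the measured compounds named here, no pair of measured compounds shows a step of this kind, so the data give no size for it. The three measured numbers sit close together in spite of their structural differences. Compound 4 is expected to stay near compound 2, with a step of a 1.4-fold lower number from compound 2 to compound 4 (0.16 log units; within the scatter) that is expected to be of no size beyond the scatter. Compound 4 is therefore estimated at 45000 nM, with a range from 15000 nM to 130000 nM.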

Compound 4, concentration lethal to 50% of the cells: 4570 nM
Compound 4: the middle estimate sits 9.8-fold (0.99 log units) above what was measured; measured number outside the range, below it.
By their numbers in this assay, from the lowest: compound 4; then compounds 1, 3 and 2 (each within the scatter of the next).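

In this assay, for the compounds shown here, chloro in place of hydrogen on an aromatic carbon, between two ring nitrogen atoms, gives a 14-fold lower number from compound 2 to compound 4 (1.15 log units; beyond the scatter), the only step so far that lies beyond the scatter. The numbers of the three earlier compounds lay within the scatter of one another and pointed to no place where a change moved the number; this position is such a place, and a single added heavy atom is enough to show it. Nothing available bears on why the number falls at this position.

Going by these compounds, it remains open whether the step belongs to chloro itself or would also appear with another group here, such as an amine or a methoxy group. On these data alone, it is also open whether the same chloro would give a step of this size on compound 1 or compound 3.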